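The source may hold more compounds than are shown below. What is called first, only, known or untested is meant among the compounds shown, and "the series" means these compounds.

Compound 1 `CCN(CC)CCCNc1ccnc2cc(Cl)ccc12` and compound 2 `CCN(CC)CCCNc1ccnc2cc(C(F)(F)F)ccc12` share one core, while compound 3 `FC(F)(F)c1ccc2c(NCCCN3CCN(c4ccnc5cc(Cl)ccc45)CC3)ccnc2c1` and compound 4 `FC(F)(F)c1ccc2c(NCCCN3CCN(c4ccnc5cc(C(F)(F)F)ccc45)CC3)ccnc2c1` share another; how the two cores differ is not broken down here. In an ADME assay on MCF-10A cells (Homo sapiens) for antiproliferative activity, read by sulforhodamine B assay, with a stated time of 48 h (on this read-out lower numbers stand for stronger inhibition of growth and higher numbers for weaker inhibition of growth), compound 1 gives 65300 nM and compound 2 gives 45800 nM. The change between them, (trifluoromethyl in place of chloro on an aromatic carbon), made a 1.4-fold lower number from compound 1 to compound 2 (0.15 log units; within the scatter). In this assay compound 3 gives 8840 nM. The change from compound 3 to compound 4 is the same one, (trifluoromethyl in place of chloro on an aromatic carbon), at a place described in exactly the same words. Because the earlier step was a 1.4-fold lower number from compound 1 to compound 2 (0.15 log units; within the scatter), compound 4 is expected to move only a little from compound 3, by about a 1.4-fold lower number from compound 3 to compound 4 (0.13 log units; within the scatter). The estimate for compound 4 is therefore 6500 nM, with a likely range from 2500 nM to 17000 nM.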

Compound 4, concentration for 50% growth inhibition: 30000 nM
Estimate against measurement, compound 4: 4.6-fold (0.66 log units) below, outside the stated range (above it).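

On the second core, the swap of chloro for trifluoromethyl gave a 3.4-fold higher number from compound 3 to compound 4 (0.53 log units; beyond the scatter). The change therefore did not act alike on the two cores in this assay: the same change on two cores in this assay, a 1.4-fold lower number (0.15 log units; within the scatter) from compound 1 to compound 2 and a 3.4-fold higher number (0.53 log units; beyond the scatter) from compound 3 to compound 4, 4.8-fold (0.68 log units) apart, beyond the scatter of two such steps

So a step measured on one core is a poor guide to the same step on the other core in this series, yet with only one pair per core, this does not show what in the cores sets the two steps apart. The compounds shown leave open how other groups at this place, such as a methyl, a methoxy or a nitrile, would compare across the two cores. They also leave open whether a longer chain in the side arm would alter the step.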